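A coumarin hydrazone series: replacing 2-methylphenyl with pyridin-3-yl

The compounds below may be only part of what the source reports. "The series", "measured", "known", "first", "only" and "open" are said of these compounds alone.

The compounds share a core that carries a double-bonded nitrogen, and they were compared in an assay on isolated protein for inhibition of myosin-2 (Bos taurus), read by spectrophotometry, with a stated time of 24 min; a higher number here means a weaker inhibitor, a lower number a stronger inhibitor. Compound 1 `C/C(=N\Nc1ccccc1)c1c(O)c2ccccc2oc1=O` gives 27000 nM in this assay. Compound 2 `C/C(=N\Cc1cccc(C)c1)c1c(O)c2ccccc2oc1=O` gives 4900 nM in this assay. Compound 3 `C/C(=N\Cc1ccccc1C)c1c(O)c2ccccc2oc1=O` reaches only the limit of this assay, >= 100000 nM, so no number is known for it; this is the limit of >= 100000 nM in this assay, at which 1 of the 3 values shown sits. Among the compounds with values here, the one measured change at the saturated chain carbon bound to the double-bonded nitrogen, an at least 20-fold higher number from compound 2 to compound 3 (1.30 log units; beyond the scatter), was therefore large and pointed toward weaker inhibition.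

Compound 4 `C/C(=N\Cc1cccnc1)c1c(O)c2ccccc2oc1=O` has not yet been measured in this assay. It differs from compound 3 by pyridin-3-yl in place of 2-methylphenyl on a saturated chain carbon bound to a double-bonded nitrogen.

Within the data shown here, only the step from compound 2 to compound 3 bears directly on this place, and it shows that the 2-methylphenyl group is the one change that carried a compound to the limit. Compound 4 removes that group, so the expectation is a step back toward the numbers of compound 2 and compound 1, estimated as an at least 6.6-fold lower number from compound 3 to compound 4 (0.82 log units; beyond the scatter). Since compound 3 stands at a limit, the size of that step is uncertain. Compound 4 is expected to give about 15000 nM in this assay, within the range 3000 nM to 100000 nM.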

Compound 4, half-maximal inhibitory concentration: 17000 nM
Estimate against measurement, compound 4: 1.1-fold (0.05 log units) below; the measured number falls inside the stated range.
By their numbers in this assay, from the lowest: compound 2; then compounds 4 and 1 (each within the scatter of the next). At a limit, above all of these: compound 3.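

In this assay, pyridin-3-yl in place of 2-methylphenyl on the saturated chain carbon brings the series back from the limit to a measured number, with an at least 5.8-fold lower number from compound 3 to compound 4 (0.76 log units; beyond the scatter), but this step is only a bound because compound 3 stands at a limit: the limit of >= 100000 nM in this assay, at which 1 of the 4 values shown sits.

The recovery is partial, with a 3.5-fold higher number from compound 2 to compound 4 (0.54 log units; beyond the scatter), so a ring without a methyl group and with a ring nitrogen escapes the limit but remains on the weaker side of the 3-methylphenyl group of compound 2. Changing the whole group on the double-bonded nitrogen gives a 1.6-fold lower number from compound 1 to compound 4 (0.20 log units; within the scatter), which lies within the scatter, so (pyridin-3-yl)methyl and anilino cannot be told apart here.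

The compounds shown cannot separate the loss of the methyl group from the entry of the ring nitrogen, since a plain benzyl group on the double-bonded nitrogen is not among them. They also leave open how pyridin-2-yl, pyridin-4-yl, a longer chain before the ring, or an amine on the ring would read at this place.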